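Stereoisomers of a hydroxylated piperidine carboxylic acid against the cytosolic enzyme

The compounds below may be only part of what the source reports. "The series", "measured", "known", "first", "only" and "open" are said of these compounds alone.

Measured so far:
compound 1, `O=C(O)[C@H]1NC[C@H](O)[C@@H](O)[C@@H]1O`: 43%
compound 2, `O=C(O)[C@H]1NC[C@H](O)[C@@H](O)[C@H]1O`: 2.6%

Compound 1 and compound 2 share all atoms and bonds. In an assay on isolated protein for inhibition of cytosolic endo-beta-N-acetylglucosaminidase (Homo sapiens), tested at 1000 uM (a higher number here means more inhibition at the concentration tested (going by the name of the read-out), a lower number less inhibition), compound 1 gives 43%, while compound 2 gives 2.6%, the lowest of the two numbers. The step of a number 40.4 percentage points lower from compound 1 to compound 2 (beyond the scatter) is attributed to the fact that compounds 1 and 2 differ only in the configuration as drawn, since nothing else separates the two.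

Compound 3, `O=C(O)[C@H]1NC[C@@H](O)[C@H](O)[C@@H]1O`, is not yet measured. Relative to compound 2 the change is the two compounds have the same atoms and bonds and differ only in configuration as drawn: 3 of 4 stereo elements differ; a stereocentre at a saturated ring carbon is drawn S in compound 2 and R in compound 3; a stereocentre at a saturated ring carbon is drawn R in compound 2 and S in compound 3; a stereocentre at a saturated ring carbon is drawn S in compound 2 and R in compound 3. Among the compounds with values here, only one measured step bears on it, a number 40.4 percentage points lower from compound 1 to compound 2 (beyond the scatter), which shows that altering a single stereocentre in this core can move the read-out by a large amount. Compound 3 also differs from compound 1 in configuration alone, so its values cannot be predicted from compound 1 directly; the two measured values merely show that this series spans from modest to negligible inhibition.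

Within the data shown here, for compound 3 the expected outcome is 10%, within 0% to 40%, estimated as the step of a number 7.4 percentage points higher from compound 2 to compound 3 (within the scatter), with wide uncertainty given that no measured pair matches this combination of inversions.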

Compound 3, a percentage reported as inhibition, at one concentration (the size of the read-out at that concentration, not a potency): 42%
For compound 3 the middle estimate is 32 percentage points below the measured one, and the stated range ends below it.
By their numbers in this assay, from the lowest: compound 2; then compounds 3 and 1 (each within the scatter of the next).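

A second arrangement of the stereocentres holds the read-out in this assay: the comparison with the first arrangement gives a number 1 percentage points lower from compound 1 to compound 3 (within the scatter), with 2 of 4 stereo elements differing, so the low value of compound 2 is not a general result of departing from the configuration of compound 1. The other comparison gives a number 39.4 percentage points higher from compound 2 to compound 3 (beyond the scatter), with 3 of 4 stereo elements differing, and across these three compounds the count of differing stereocentres does not follow the read-out, as the single difference gives the large drop while the double difference gives no change beyond the scatter. This large step can be set down to stereochemistry alone: the fact that compounds 2 and 3 differ only in the configuration as drawn

Going by these compounds, the steps to compound 3 change several stereocentres at once, and which of them carries the difference stays open. Also open, on these data alone, is whether the inhibition needs the carboxylic acid, or whether a primary amide or a methyl ester in its place on the core of compound 1 or compound 3 would keep it.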